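Naphthyl to Phenyl on a Dienone Core

The source may report more compounds than this note shows. Statements on the series, on what has been measured and on what is new or still open speak of the compounds shown alone.

Measured so far:
compound 1 `COc1cc(/C=C/C(=O)/C=C/c2cccc3ccccc23)ccc1OCc1cn(CCCCOc2cc(=O)oc3ccccc23)nn1`: 56%
compound 2 `COc1ccc(/C=C/C(=O)/C=C/c2ccc(OCc3cn(CCOc4cc(=O)oc5ccccc45)nn3)c(OC)c2)cc1`: 71%
compound 3 `COc1cccc(/C=C/C(=O)/C=C/c2ccc(OCc3cn(CCOc4cc(=O)oc5ccccc45)nn3)c(OC)c2)c1`: 70%

In a functional assay on HCT-116 cells (Homo sapiens) for inhibition, read by sulforhodamine B assay, with a stated time of 48 h, tested at 50 uM (on this read-out lower numbers stand for less inhibition of growth and higher numbers for more inhibition of growth at the one concentration tested), compound 1 gives 56%, the lowest of the three numbers; the nearest is compound 3 with 70%, a gap beyond the scatter, and the furthest is compound 2 with 71%, also beyond the scatter. Compound 4 `COc1cc(/C=C/C(=O)/C=C/c2ccccc2)ccc1OCc1cn(CCCCOc2cc(=O)oc3ccccc23)nn1` has not yet been measured. It differs from compound 1 by phenyl in place of naphthalen-1-yl on a double-bonded chain carbon bound to a double-bonded chain carbon.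

Among the measured compounds shown here, the only measured step between compounds that differ in one place, a number 1 percentage points lower from compound 2 to compound 3 (within the scatter), swaps one methoxyphenyl for another and lies within the scatter; it does not touch the naphthalen-1-yl group and so says little about the change at hand. For the measured compounds named here, compounds 2 and 3 both carry a substituted phenyl rather than naphthalen-1-yl, but they also differ from compound 1 in the chain to the coumarin, so their values show only that phenyl-bearing members of this set reach higher numbers.

Compound 4 is therefore expected to give roughly 62%, between 45% and 78%, an estimated step of a number 6 percentage points higher from compound 1 to compound 4 (within the scatter) that may well stay within the scatter.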

Compound 4, percent growth inhibition at one concentration: 34%
Estimate against measurement, compound 4: 28 percentage points above; the measured number lies below the stated range.
By their numbers in this assay, from the lowest: compound 4; then compound 1; then compounds 3 and 2 (each within the scatter of the next).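

In this assay, putting phenyl in place of naphthalen-1-yl on a double-bonded chain carbon bound to a double-bonded chain carbon gives a number 22 percentage points lower from compound 1 to compound 4 (beyond the scatter), with the rest of the structure unchanged. This is the first single change shown that moves the read-out beyond the scatter, and it ties the larger aromatic group to more inhibition of growth for this pair at the one concentration tested, whereas a number 1 percentage points lower from compound 2 to compound 3 (within the scatter) only moved a methoxy group on the phenyl ring and gave no readable difference. Nothing available accounts for the direction or size of the step between compound 1 and compound 4.

The compounds shown leave open whether the same exchange of naphthalen-1-yl for phenyl would give a step of similar size with the chain to the coumarin found in compound 2 and compound 3. They also leave open how this place would respond to naphthalen-2-yl, or to a phenyl carrying a dimethylamino group or a carboxylic acid, and so whether the trend follows the number of aromatic rings or something else about the group.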